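Chloro-phenyl thiosemicarbazone variant of the pyridyl ether series

The source may hold more compounds than are shown below. What is called first, only, known or untested is meant among the compounds shown, and "the series" means these compounds.

Compound 2 `COc1cc2c(Oc3ccc(NC(=O)N/N=C/c4cccs4)cc3F)ccnc2cc1OCCCN1CCCCC1` gives 770 nM in a functional assay on HT-29 cells (Homo sapiens) for cytotoxicity, read by MTT assay, with a stated time of 72 h; on this read-out higher numbers stand for weaker inhibition and lower numbers for stronger inhibition. Its only neighbour is compound 1 `C=CCc1cccc(/C=N/NC(=O)Nc2ccc(Oc3ccnc4cc(OCCCN5CCCCC5)c(OC)cc34)c(F)c2)c1OC`, which in this assay gives 460 nM; the step of a 1.7-fold higher number from compound 1 to compound 2 (0.22 log units; within the scatter) lies within the scatter, so the two numbers are indistinguishable on the evidence shown. Compound 3 `COc1cc2c(Oc3ccc(NC(=S)N/N=C/c4ccc(Cl)cc4)cc3F)ccnc2cc1OCCCN1CCCCC1` is not yet measured. It differs from compound 2 by a group of 12 heavy atoms (8 carbon, 2 nitrogen, 1 sulfur, 1 chlorine; one six-membered aromatic ring of carbon only) in place of a group of 10 heavy atoms (6 carbon, 2 nitrogen, 1 oxygen, 1 sulfur; one five-membered aromatic ring with 1 hetero atom), on a nitrogen on an aromatic ring. Going by the values given here, the one measured step, from compound 1 to compound 2, exchanges the ring on the carbon with a double bond to nitrogen and was within the scatter; it does not touch the oxygen-to-sulfur part of the present change, and no measured pair does. No step beyond the scatter is therefore expected; compound 3 is estimated at 650 nM, with a range of 200 nM to 2100 nM, the expected step being a 1.2-fold lower number from compound 2 to compound 3 (0.07 log units; within the scatter).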

Compound 3, half-maximal inhibitory concentration: 190 nM
Beside the measured number, compound 3's estimate is 3.4-fold (0.53 log units) above it; measured number outside the range, below it.
By their numbers in this assay, from the lowest: compound 3; then compounds 1 and 2 (each within the scatter of the next).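

In this assay, going by these compounds alone, the exchange on the nitrogen on an aromatic ring gives a 4.1-fold lower number from compound 2 to compound 3 (0.61 log units; beyond the scatter), the first step to lie beyond the scatter; the earlier ring exchange on the carbon with a double bond to nitrogen, a 1.7-fold higher number from compound 1 to compound 2 (0.22 log units; within the scatter), did not. This position therefore responds to change, at least for this one exchange, which replaces the carbonyl with a thiocarbonyl and the five-membered aromatic ring with 1 hetero atom with a chlorine-bearing six-membered aromatic ring of carbon only. Nothing at hand explains the gain in potency.

The two parts of the exchange arrive together, so the share of the sulfur and the share of the chlorine-bearing ring remain unseparated. Also open, from the compounds shown here alone, is whether a bromine or a methoxy group in place of the chlorine would hold the lower number.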